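A few compounds are considered here, and "the series" means these few. Any claim that something is new, unique, unknown or untested is made for them only; others in the source may bear on it.

Compound 1 `CCC(=O)c1ccc(OCCCCOc2cc(C(=O)O)ccc2OC)c(C)c1O`: 162 nM in an assay on HEK293 cells for positive allosteric modulation of metabotropic glutamate receptor 2 (Rattus norvegicus), read by thallium flux, with a stated time of 2.5 min; a higher number here means that more compound is needed for the effect, a lower number that less compound is needed.
Compound 2 `COc1ccc(C(=O)O)cc1OCCCCOc1ccc(C(C)=O)c(O)c1C`: 1090 nM.
Compound 3 `Cc1cc(C(=O)O)ccc1OCCCCOc1ccc(C(=O)C(C)C)c(O)c1C`: 234 nM.

Compound 4 `CCC(=O)c1ccc(OCCCCOc2ccc(C(=O)O)cc2C)c(C)c1O` has not yet been measured in this assay. It differs from compound 3 by hydrogen in place of methyl on a saturated chain carbon bound to a carbonyl carbon and a saturated chain carbon. The same kind of change separates compound 1 from compound 2, namely (hydrogen in place of methyl on a saturated chain carbon bound to a carbonyl carbon), and in this assay it gave a 6.7-fold higher number from compound 1 to compound 2 (0.83 log units; beyond the scatter). The places are not identical: in compound 3 the carbon losing its methyl is also bound to a saturated chain carbon, whereas in compound 1 it is bound to the carbonyl carbon alone, so the change is of the same kind, not the same. The difference between the cores of compound 1 and compound 3 is not broken down here. Compound 4 is therefore expected at 500 nM, within 220 nM to 1200 nM, because a 6.7-fold higher number from compound 1 to compound 2 (0.83 log units; beyond the scatter) was seen for the same kind of change. The step that this estimate means is expected to be a 2.1-fold higher number from compound 3 to compound 4 (0.33 log units; beyond the scatter).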

Compound 4, half-maximal effective concentration: 82 nM
Compound 4: the middle estimate sits 6.1-fold (0.79 log units) above what was measured; the whole stated range lies above it.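

In this assay, replacing the methyl with hydrogen gives a 2.9-fold lower number from compound 3 to compound 4 (0.46 log units; beyond the scatter) as isopropyl becomes ethyl, which runs opposite to the earlier step. In this series, the same kind of change therefore does not carry over from one core to the other with its direction intact: the same change on two cores in this assay, a 6.7-fold higher number (0.83 log units; beyond the scatter) from compound 1 to compound 2 and a 2.9-fold lower number (0.46 log units; beyond the scatter) from compound 3 to compound 4, 19-fold (1.28 log units) apart, beyond the scatter of two such steps.

This does not show whether the core or the exact place of the change accounts for the gap, since the two steps differ in both, and two pairs cannot give a rule for other cores.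

On these data alone, it remains open how a cyclopropyl group would compare with the isopropyl and ethyl groups. Also open, as far as these compounds go, is whether a tetrazole could stand in for the carboxylic acid on either core.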